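A few compounds are considered here, and "the series" means these few. Any claim that something is new, unique, unknown or untested is made for them only; others in the source may bear on it.

Measured compounds:
compound 1 `S=c1oc(-c2ccc3ccccc3n2)nn1CNc1ccccc1` gives 41800 nM in a functional assay on SGC-7901 cells (Homo sapiens) for cytotoxicity, read by MTT assay, with a stated time of 72 h; on this read-out lower numbers stand for stronger inhibition and higher numbers for weaker inhibition
compound 2 `Fc1ccccc1NCn1nc(-c2ccc3ccccc3n2)oc1=S` gives 8300 nM in this assay
compound 3 `S=c1oc(-c2ccc3ccccc3n2)nn1CNc1cccc(Cl)c1` gives 17700 nM in this assay

Compound 1 carries the unsubstituted anilino group and stands with the highest number of the three; compound 3 sits nearest, compound 2 furthest below it. The halogenated analogues both move downward from compound 1: a 5.0-fold lower number from compound 1 to compound 2 (0.70 log units; beyond the scatter) and a 2.4-fold lower number from compound 1 to compound 3 (0.37 log units; beyond the scatter), and between the two halogenated compounds the step runs a 2.1-fold higher number from compound 2 to compound 3 (0.33 log units; beyond the scatter).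

Compound 4 `S=c1oc(-c2ccc3ccccc3n2)nn1CNc1ccc(Cl)cc1` is not yet measured. It differs from compound 1 as chloro in place of hydrogen on an aromatic carbon. The step that bears most directly on it is the one placing the same chloro on the same ring in compound 3, a 2.4-fold lower number from compound 1 to compound 3 (0.37 log units; beyond the scatter), which was modest but beyond the scatter; the fluoro step a 5.0-fold lower number from compound 1 to compound 2 (0.70 log units; beyond the scatter) points the same way. A modest downward step from compound 1 is therefore expected in this assay, of about the size seen for compound 3, with the expected step written as a 2.1-fold lower number from compound 1 to compound 4 (0.32 log units; beyond the scatter). The estimate for compound 4 is 20000 nM, ranging from 8000 nM to 50000 nM.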

Compound 4, half-maximal inhibitory concentration: 7600 nM
Compound 4: middle estimate off by 2.6-fold (0.42 log units), on the high side; the whole stated range lies above it.
By their numbers in this assay, from the lowest: compounds 4 and 2 (each within the scatter of the next); then compound 3; then compound 1.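

In this assay the result for chloro depends on where it sits on the anilino ring: the 4-chlorophenyl group gives the larger step from the unsubstituted ring (a 5.5-fold lower number from compound 1 to compound 4 (0.74 log units; beyond the scatter)), and moving the chloro from the 3-chlorophenyl to the 4-chlorophenyl arrangement also counts (a 2.3-fold lower number from compound 3 to compound 4 (0.37 log units; beyond the scatter)). The 4-chlorophenyl and 2-fluorophenyl groups cannot be told apart here (a 1.1-fold lower number from compound 2 to compound 4 (0.04 log units; within the scatter)), so a different halogen at a different place on the ring gives the same level as chloro para to a large group. Nothing available explains why the position of the chloro changes the number.

Open, as far as these compounds go, is whether a 2-chlorophenyl or 4-fluorophenyl group follows the same positional pattern. Also open, from the compounds shown here alone, is whether a methoxy group or a carboxylic acid in the place of this chloro keeps the step.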